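Acetyl to dimethylamino on the pendant phenyl ring

The compounds below may be only part of what the source reports. "The series", "measured", "known", "first", "only" and "open" are said of these compounds alone.

Compound 1 `COc1cc(C)cc(-c2c(-c3ccnc(-c4ccc(C(C)=O)cc4)c3)cnn2CC#N)c1`: 2410 nM
Compound 2 `Cc1cc(O)cc(-c2nn(CC#N)cc2-c2ccnc(-c3ccc(Oc4ccccc4)cc3)c2)c1`: 1870 nM

Both numbers come from a functional assay on NCI-H460 cells (Homo sapiens) for inhibition, read by sulforhodamine B assay, with a stated time of 48 h; on this read-out higher numbers stand for weaker inhibition of growth and lower numbers for stronger inhibition of growth. In this assay compound 1 gives 2410 nM and compound 2 gives 1870 nM; the two lie within the scatter of each other, so neither can be set apart from the other. Compound 1 and compound 2 differ in several places at once, so nothing about any single change can be read from this pair.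

Compound 3 `COc1cc(C)cc(-c2c(-c3ccnc(-c4ccc(N(C)C)cc4)c3)cnn2CC#N)c1` is not yet measured. Against compound 1 the change is dimethylamino in place of acetyl on an aromatic carbon; the shared core and the rest of the molecule are unchanged. Going by the values given here, no measured pair isolates a change at this position, so there is no basis for a step in either direction. The expected step from compound 1 to compound 3 is a 1.2-fold lower number from compound 1 to compound 3 (0.08 log units; within the scatter), which is none beyond the scatter. For compound 3 the estimate in this assay is 2000 nM, with a range from 600 nM to 6500 nM.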

Compound 3, concentration for 50% growth inhibition: 57.7 nM
Compound 3: the middle estimate sits 35-fold (1.54 log units) above what was measured, and the stated range ends above it.
By their numbers in this assay, from the lowest: compound 3; then compounds 2 and 1 (each within the scatter of the next).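

Exchanging acetyl for dimethylamino on an aromatic carbon, para to a large group, gives a 42-fold lower number from compound 1 to compound 3 (1.62 log units; beyond the scatter) in this assay, with the shared core and the rest of the molecule unchanged. Going by these compounds alone, this is the first pair to isolate this position, and it shows that growth inhibition is highly sensitive to the group held there: the two groups have equal counts of heavy atoms, hydrogen-bond donors and hydrogen-bond acceptors, and neither carries a net charge, so these counts do not separate them, while the double bond outside aromatic rings is present only in acetyl. No measurement at hand bears on the origin of a step of this size, so it stands here as an observation without an explanation.

Still open, on these data alone, is whether the large step is specific to dimethylamino or would also appear with another group at this place, such as a primary amine, a morpholine or a methoxy. Also open, as far as these compounds go, is whether it would carry over to the hydroxyl-bearing compound 2, which differs from compound 3 in several places.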